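A few compounds are considered here, and "the series" means these few. Any claim that something is new, unique, unknown or untested is made for them only; others in the source may bear on it.

Of the compounds shown here, three that share one core have been tested in a functional assay on the whole organism (strain Kunming) with Mus musculus as the target, with a stated time of 0.5 h, at a dose of 300 mg/kg by the intraperitoneal route (on this read-out lower numbers stand for a stronger effect and higher numbers for a weaker effect at the one dose given), so far. Compound 1, `COc1cc(OC)c(OC)cc1/C=C/COC(=O)/C=C/c1ccc(Br)cc1`, gives 25% in this assay. Compound 2, `COc1cc(OC)c(OC)cc1/C=C/COC(=O)/C=C/c1cc(OC)c(OC)c(OC)c1`, gives 25% in this assay, and compound 3, `COc1cc(OC)c(OC)cc1/C=C/COC(=O)/C=C/c1ccc(OC)c(OC)c1OC`, gives 25% in this assay. On these numbers compound 1 stands level with compound 2 and with compound 3 at the digits reported, and the two gaps are within the usual scatter, so no order among the three can be read from them. The change on the far aromatic ring between compound 2 and compound 3, and the exchange of that ring for a bromine-bearing one in compound 1, left the read-out unmoved.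

Compound 4, `COc1cccc(/C=C/C(=O)OC/C=C/c2cc(OC)c(OC)cc2OC)c1`, has not yet been measured in this assay. It differs from compound 1 as follows: 3-methoxyphenyl in place of 4-bromophenyl on a double-bonded chain carbon bound to a double-bonded chain carbon. Going by the values given here, no step between measured compounds is recorded that would show how a change of this kind acts in this assay. The step of a number 1 percentage points higher from compound 1 to compound 4 (within the scatter) is therefore expected to be none beyond the scatter. Because compound 1 gives 25%, because compound 2 gives 25% and because compound 3 gives 25% with other groups on the same ring, compound 4 is expected to give about 26% in this assay, within a range from 14% to 40%.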

Compound 4, a percentage reported as activity, at one dose (the size of the read-out at that dose, not a potency): 50%
The estimate for compound 4 lay 24 percentage points below the measured number; measured number outside the range, above it.
By their numbers in this assay, from the lowest: compounds 1, 2 and 3 (each within the scatter of the next); then compound 4.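

In this assay, going by these compounds alone, the exchange of 4-bromophenyl for 3-methoxyphenyl on a double-bonded chain carbon bound to a double-bonded chain carbon gives a number 25 percentage points higher from compound 1 to compound 4 (beyond the scatter), which shows that this place is not indifferent to the group it carries, as the level numbers of the earlier compounds alone might have suggested. A methoxy group on this ring does not by itself go with the weaker effect: compound 2 gives 25% and compound 3 gives 25% in this assay, and both carry methoxy groups on that ring, so the outcome depends on more than the presence of such a group. Nothing available bears on why the number rose with this change.

The compounds shown leave open whether the higher number for compound 4 reflects the loss of the bromine or the particular 3-methoxyphenyl arrangement, a question that a plain phenyl group at this place would help to settle. They also leave open how this place would respond to an amine or a carboxylic acid on the ring, and how any of these results would hold at doses other than the single one given.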